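This account rests on a few compounds, and the source may have more. Where it says the series, first, only, none or still open, it means among the compounds named here.

Compound 3 `NC(=O)/C=C1\CCc2ccc(F)cc21` carries the shared core with an unsubstituted amide nitrogen. In a functional assay on the whole organism with Mus musculus as the target (a lower number here means that less compound is needed, a higher number that more compound is needed for the effect), compound 3 gives 56 mg/kg, the lowest of the two numbers shown. Compound 1 `CC(C)NC(=O)/C=C1\CCc2ccc(F)cc21` gives 96 mg/kg in this assay. For compound 2 `CCCNC(=O)/C=C1\CCc2ccc(F)cc21` this assay reports only a limit, > 100 mg/kg (the limit of > 100 mg/kg in this assay, at which 1 of the 3 values shown sits). The two measured steps that arrive at compound 3 are a 1.7-fold lower number from compound 1 to compound 3 (0.23 log units; within the scatter) and an at least 1.7-fold lower number from compound 2 to compound 3 (0.25 log units; that floor lies within the scatter), and neither leaves the scatter. Compound 4 `O=C(/C=C1\CCc2ccc(F)cc21)NC1CC1` differs from compound 3 in one place: cyclopropyl in place of hydrogen on an amide-type nitrogen. Because a 1.7-fold lower number from compound 1 to compound 3 (0.23 log units; within the scatter) and an at least 1.7-fold lower number from compound 2 to compound 3 (0.25 log units; that floor lies within the scatter) both stayed within the scatter, a step no larger than the scatter is expected here, a 1.3-fold higher number from compound 3 to compound 4 (0.10 log units; within the scatter), toward a somewhat higher number if anything. Compound 4 is therefore estimated at 70 mg/kg, between 35 mg/kg and 140 mg/kg.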

Compound 4, dose for half-maximal effect: 66 mg/kg
For compound 4 the middle estimate is 1.1-fold (0.03 log units) above the measured one, and the stated range covers the measured number.
By their numbers in this assay, from the lowest: compounds 3, 4 and 1 (each within the scatter of the next). At a limit, above all of these: compound 2.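

With cyclopropyl, a ring now sits on this amide-type nitrogen, and the number in this assay stays close to that with hydrogen (a 1.2-fold higher number from compound 3 to compound 4 (0.07 log units; within the scatter)) and that with isopropyl (a 1.5-fold lower number from compound 1 to compound 4 (0.16 log units; within the scatter)). Against propyl only a floor can be read (an at least 1.5-fold lower number from compound 2 to compound 4 (0.18 log units; that floor lies within the scatter)). Compound 2 stands at a limit: the limit of > 100 mg/kg in this assay, at which 1 of the 4 values shown sits.

The compounds shown leave open whether any group on this nitrogen moves the number beyond the scatter. A longer chain, an amine or a carboxylic acid there would test this.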